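Swapping the pyridine amide for a methylsulfonylphenyl amide

The source may report more compounds than this note shows. Statements on the series, on what has been measured and on what is new or still open speak of the compounds shown alone.

Measured compounds:
compound 1 `O=C(Nc1ccc(Cl)c(-c2nnc3c(Cl)cccn23)c1)c1cccnc1`: > 100000 nM
compound 2 `CS(=O)(=O)c1ccc(C(=O)Nc2ccc(Cl)c(-c3nnc4c(Cl)cccn34)c2)c(Cl)c1`: > 100000 nM
compound 3 `O=C(Nc1ccc(Cl)c(-c2nnc3c(Cl)cccn23)c1)c1ccccc1`: 67600 nM

In a functional assay on AN3-CA cells (Homo sapiens) for antiproliferative activity, read by MTT assay, with a stated time of 72 h (a higher number here means a weaker inhibitor, a lower number a stronger inhibitor), compound 1 sits at a limit, not a number, namely (the limit of > 100000 nM in this assay, at which 2 of the 3 values shown sit). Compound 2 rests at that same limit. Among the measured compounds shown here, compound 3 alone gives a number, and the only measured step, an at least 1.4-fold lower number from compound 1 to compound 3 (0.17 log units; that floor lies within the scatter), stays within the scatter. Compound 4 `CS(=O)(=O)c1cccc(C(=O)Nc2ccc(Cl)c(-c3nnc4c(Cl)cccn34)c2)c1` differs from compound 1 by 3-(methylsulfonyl)phenyl in place of pyridin-3-yl on a carbonyl carbon. For the measured compounds named here, no measured step covers this exact change; compound 2, which also carries a methylsulfonyl group on its amide ring, stayed at the limit, and compound 3 moved little. A step of a number no higher from compound 1 to compound 4 (the limit leaves the size open) is therefore expected, with no clear gain. Compound 4 is estimated at 100000 nM, between 40000 nM and 300000 nM, quite possibly again only a limit.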

Compound 4, half-maximal inhibitory concentration: > 100000 nM
Compound 4 ended at the assay's limit; the forecaster's own chance of this, stated with the estimate: 55%; the middle value lies on the limit itself.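

In this assay methylsulfonyl on the phenyl ring of the amide gives an at least 1.4-fold higher number from compound 3 to compound 4 (0.17 log units; that floor lies within the scatter) and so shows no gain over the plain phenyl ring. The step from compound 1 to compound 4 cannot be read because both values are limits of the assay: the limit of > 100000 nM in this assay, at which 3 of the 4 values shown sit. Among the compounds shown here, compound 3 remains the only compound here with a number.

As far as these compounds go, how far compound 1 and compound 4 lie past that limit stays open. Also open, from the compounds shown here alone, is whether an amine or a carboxylic acid in place of methylsulfonyl would lower the number of compound 3 (67600 nM).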